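The source may report more compounds than this note shows. Statements on the series, on what has been measured and on what is new or still open speak of the compounds shown alone.

Compound 1, `CSc1ccc(F)cc1NCC1=NCCN1`, is the starting point of this comparison. In an assay on CHO cells for binding affinity to Alpha-2B adrenergic receptor (Homo sapiens), read by radioligand binding (on this read-out lower numbers stand for stronger inhibition and higher numbers for weaker inhibition), compound 1 gives 331 nM, which is the only outright number available among the compounds shown here. One further value exists, but it is a limit rather than a number: for compound 2, `CS(=O)(=O)c1cc(F)ccc1NCC1=NCCN1`, this assay reports only < 6310 nM. That limit, (the limit of < 6310 nM in this assay, at which 1 of the 2 values shown sits), marks the edge of what the assay could resolve, so compound 1 stands alone as a measured reference.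

The compound of interest, compound 3, `CSc1ccc(C)cc1NCC1=NCCN1`, has not yet been measured in this assay. It differs from compound 1 in one place: methyl in place of fluoro on an aromatic carbon. Within the data shown here, no step between two measured compounds is available to guide this particular change, so the expectation rests only on compound 1 and its value of 331 nM.

For compound 3 the expected step from compound 1 is a 1.2-fold higher number from compound 1 to compound 3 (0.08 log units; within the scatter), that is, no change beyond the usual scatter of repeated measurements. Compound 3 is therefore estimated to give 400 nM, with a likely range from 150 nM to 1200 nM.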

Compound 3, inhibition constant: 977 nM
Beside the measured number, compound 3's estimate is 2.4-fold (0.39 log units) below it; the measured number falls inside the stated range.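

In this assay the exchange of fluoro for methyl, on the aromatic carbon para to the methylsulfanyl group, gives a 3.0-fold higher number from compound 1 to compound 3 (0.47 log units; beyond the scatter) and so is not a neutral swap. Until now only compound 1 offered a measured number, so nothing showed whether this carbon responds to the group placed on it; this single pair shows that it does, and since a higher number stands for weaker inhibition, compound 1 with its fluoro is the stronger of the two. Nothing among the data shown accounts for the size or the direction of this step.

Going by these compounds, with only fluoro and methyl to compare at this position, it remains open whether a chlorine atom, a methoxy group or an amine on the same carbon would give a lower or a higher number than compound 1. On these data alone, it is also open whether the exchange of fluoro for methyl would give a step of similar size if an ethylsulfanyl group, a longer chain, stood in place of the methylsulfanyl group.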